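This account rests on a few compounds, and the source may have more. Where it says the series, first, only, none or still open, it means among the compounds named here.

Measured so far in a functional assay on HEK293 cells for agonist activity at D(4) dopamine receptor (Homo sapiens), read by FLIPR; on this read-out higher numbers stand for larger maximal responses and lower numbers for smaller maximal responses:
- compound 1 `O=C(NCN1CCC(c2cccc[n+]2[O-])CC1)c1ccccc1` gives 63%
- compound 2 `O=C(NCN1CCC(c2cccc[n+]2[O-])CC1)c1cnccc1Cl` gives 44%

Compound 2 stands lowest of the two numbers. Among the measured compounds shown here, its nearest neighbour is compound 1, and the only measured step, a number 19 percentage points lower from compound 1 to compound 2 (beyond the scatter), runs between them: a 4-chloropyridin-3-yl in place of phenyl on the carbonyl carbon.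

Compound 3 `O=C(NCN1CCC(c2cccc[n+]2[O-])CC1)c1ccc(F)c(Cl)c1` is not yet measured. It differs from compound 2 in one place: 3-chloro-4-fluorophenyl in place of 4-chloropyridin-3-yl on a carbonyl carbon. The change thus takes the carbonyl substituent back from a pyridine-type ring to a carbon-only ring, now carrying chlorine and fluorine.

For the measured compounds named here, only the step from compound 1 to compound 2 bears on this. It was modest and beyond the scatter, and it went downward when a phenyl gave way to the 4-chloropyridin-3-yl. Going by the values given here, the reverse sense of the present change, toward a carbon-only aromatic ring, suggests an upward move in this assay, though the added halogens have no measured counterpart here. Compound 3 is therefore expected to recover part of the difference, because compound 1 gives 63% against compound 2 at 44%. The expected step is a number 13 percentage points higher from compound 2 to compound 3 (beyond the scatter). For compound 3 the estimate is 57%, with a range from 42% to 72%.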

Compound 3, largest response reached (reported as efficacy), in percent of the reference or control that the assay uses: 67%
Estimate against measurement, compound 3: 10 percentage points below; the measured number falls inside the stated range.
By their numbers in this assay, from the lowest: compound 2; then compounds 1 and 3 (each within the scatter of the next).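

In this assay, putting 3-chloro-4-fluorophenyl in place of 4-chloropyridin-3-yl on the carbonyl carbon gives a number 23 percentage points higher from compound 2 to compound 3 (beyond the scatter) and so reverses the loss seen with the pyridine-type ring. Set against the plain phenyl, the same group gives a number 4 percentage points higher from compound 1 to compound 3 (within the scatter) and so shows that this position accepts a chlorine and a fluorine on the carbon-only ring with no readable change in maximal response. Among these three compounds, only the 4-chloropyridin-3-yl group stands apart from the others, but nothing measured here explains the difference at this position.

On these data alone, it remains open whether the lower response of compound 2 follows the ring nitrogen or the chlorine, which an unsubstituted pyridin-3-yl group would help to separate, and whether a single halogen, as in 4-fluorophenyl or 3-chlorophenyl, would read like compound 1 and compound 3. Also open, as far as these compounds go, is how a carboxylic acid, a dimethylamino group or a methoxy group on this ring would behave in this assay.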